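Ethyl Added to a Ring-Bound Methyl Chain

This account rests on a few compounds, and the source may have more. Where it says the series, first, only, none or still open, it means among the compounds named here.

Compound 3 `CCNC(=O)Nc1cccc(S(=O)(=O)Oc2ccccc2C)c1`, compound 1 `Cc1ccccc1OS(=O)(=O)c1cccc(NC(=O)NCCCCl)c1` and compound 2 `CCCc1ccccc1NS(=O)(=O)c1ccc(NC(=O)NCCCCl)cc1` share a sulfonyl-linked core carrying a urea, and all three were tested in a functional assay on MCF7 cells (Homo sapiens) for cytotoxicity, read by sulforhodamine B assay, with a stated time of 48 h; a lower number here means a stronger inhibitor, a higher number a weaker inhibitor. Compound 3 gives 55000 nM, compound 1 gives 27000 nM, and compound 2 gives 35000 nM. Compound 3 thus carries the highest of the three numbers; its gap to compound 2 lies within the scatter, while the step of a 2.0-fold higher number from compound 1 to compound 3 (0.31 log units; beyond the scatter) lies beyond it.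

Compound 4 `CCCc1ccccc1OS(=O)(=O)c1cccc(NC(=O)NCC)c1` is the next compound. The change from compound 3 is ethyl in place of hydrogen on a saturated chain carbon bound to an aromatic carbon, which, read one bond further out, is methyl to propyl. Among the measured compounds shown here, no measured step covers this change: the only step that has been measured alters the urea chain at the other end of the molecule, and compound 2 with its propyl group differs from the others in several places at once, so its value cannot be tied to the propyl alone. Compounds 1 and 2, which differ in more than one place, show numbers that lie close to each other.

With nothing to suggest otherwise, the step of a 1.1-fold lower number from compound 3 to compound 4 (0.04 log units; within the scatter) is expected to stay within the scatter. Compound 4 is therefore estimated at 50000 nM, between 22000 nM and 115000 nM.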

Compound 4, half-maximal inhibitory concentration: 24000 nM
Beside the measured number, compound 4's estimate is 2.1-fold (0.32 log units) above it; the range from low to high includes it.
By their numbers in this assay, from the lowest: compounds 4, 1, 2 and 3 (each within the scatter of the next, the first and the last beyond it).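

In this assay, among the compounds shown here, the step of a 2.3-fold lower number from compound 3 to compound 4 (0.36 log units; beyond the scatter) is the first measured change at this position, and it shows that the chain on the saturated carbon bound to an aromatic carbon is not a silent place in the molecule. Going from methyl to propyl here moves the number beyond the scatter and towards a stronger inhibitor, though only modestly, while the urea chain stays the same. So the number responds to changes in at least two places: this chain and the chloromethyl-bearing urea chain examined earlier, and no measurement shown gives a reason for this shift.

As far as these compounds go, what stays open is whether the lower number continues with a longer chain such as butyl, or whether propyl is already the limit of the trend, and whether a phenyl ring or an amine at the end of the chain would fit the same picture. Also open, from the compounds shown here alone, is whether the step from methyl to propyl keeps its size when the urea carries the chloromethyl-bearing chain of compound 1 in place of the ethyl of compound 3 and compound 4.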